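A sulfonyl in place of a sulfanyl in compound 3

The compounds below may be only part of what the source reports. "The series", "measured", "known", "first", "only" and "open" are said of these compounds alone.

- compound 1 (`O=C(O)c1ccc(C(=O)/C(=C\c2ccc(F)c([N+](=O)[O-])c2)SCc2ccc(Cl)cc2Cl)cc1`) gives < 1000 ug/mL
- compound 2 (`O=C(O)c1ccc(C(=O)/C(=C\c2ccc(Cl)c([N+](=O)[O-])c2)SCc2ccc(Cl)cc2)cc1`) gives < 1000 ug/mL

In a physicochemical assay for solubility (a higher number here means a more soluble compound, a lower number a less soluble compound), compound 1 stands only at a limit (< 1000 ug/mL), not at a number. Compound 2 is likewise known only as a limit (< 1000 ug/mL). Together they give one bound (the limit of < 1000 ug/mL in this assay, at which 2 of the 2 values shown sit). Compound 3 (`O=C(O)c1ccc(C(=O)/C(=C\c2ccc(F)c([N+](=O)[O-])c2)S(=O)(=O)Cc2ccc(Br)cc2)cc1`) carries (4-bromobenzyl)sulfonyl in place of (2,4-dichlorobenzyl)sulfanyl on a double-bonded chain carbon bound to a carbonyl carbon and a double-bonded chain carbon. For the measured compounds named here, no measured step guides this change. No step beyond the scatter is expected, and the estimated step is small (a step that the limit leaves unreadable from compound 1 to compound 3). For compound 3 the expected solubility is 500 ug/mL, estimated to lie from 100 ug/mL to 1000 ug/mL.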

Compound 3, solubility: < 1000 ug/mL
Compound 3: a limit, no number; the forecaster's own chance of this, stated with the estimate: 75%; the middle value does not contradict the limit.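

Compound 3 also stands only at a limit in this assay, so no step from compound 1 to compound 3 can be read: the limit of < 1000 ug/mL in this assay, at which 3 of the 3 values shown sit.

Going by these compounds, what number either compound would reach in this assay stays open, and with it the size of any step between them.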